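Thiophene for Methoxyphenyl: Expecting Compound 4

The compounds below may be only part of what the source reports. "The series", "measured", "known", "first", "only" and "open" are said of these compounds alone.

Compound 1, `C(#Cc1nc(-c2ccccc2)nc2c1ncn2Cc1ccccc1)c1ccccc1`: 100%
Compound 2, `C(=C/c1[nH]cnc2ncnc1-2)\c1ccccc1`: 28%
Compound 3, `COc1ccc(/C=C/c2ncnc3c2ncn3C2CCOCC2)cc1`: 58%

All three values come from a functional assay on K562 cells (Homo sapiens) for inhibition, read by thymidine incorporation, with a stated time of 48 h, tested at 10 ug/mL; a lower number here means less inhibition, a higher number more inhibition at the concentration tested (going by the name of the read-out). Compound 3 gives the second highest of the three numbers: compound 2 lies below it by a gap beyond the usual scatter, and compound 1 lies above it, also beyond the scatter. Compound 4, `C(=C/c1ncnc2c1ncn2C1CCOCC1)\c1ccsc1`, has not yet been measured. It differs from compound 3 in one place: thiophen-3-yl in place of 4-methoxyphenyl on a double-bonded chain carbon bound to a double-bonded chain carbon. For the measured compounds named here, no measured pair shows a change of this kind, so there is no step to lean on. The expected step of a number 8 percentage points lower from compound 3 to compound 4 (within the scatter) is a small drop, within the scatter. Compound 4 is therefore expected to give about 50%, with a range from 25% to 75%.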

Compound 4, a percentage reported as inhibition, at one concentration (the size of the read-out at that concentration, not a potency): 58%
For compound 4 the middle estimate is 8 percentage points below the measured one, within the range that was stated.
By their numbers in this assay, from the lowest: compound 2; then compounds 3 and 4 (each within the scatter of the next); then compound 1.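

In this assay thiophen-3-yl in place of 4-methoxyphenyl gives no change at the digits printed from compound 3 to compound 4 (within the scatter) as the first step measured at this place. On this double-bonded chain carbon, then, a five-membered aromatic ring with fewer heavy atoms and a sulfur serves as well as the six-membered carbon ring with its oxygen-bearing group. Nothing measured here explains this result. The compounds shown leave open whether an amine or a carboxylic acid at this place would also leave the number unchanged. They also leave open whether a saturated ring such as cyclohexyl would do so.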